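Bis-benzimidazole series: methoxy to nitro on the central ring

The compounds below may be only part of what the source reports. "The series", "measured", "known", "first", "only" and "open" are said of these compounds alone.

Compound 1 `COc1cc(-c2nc3ccc([N+](=O)[O-])cc3[nH]2)cc(-c2nc3ccc([N+](=O)[O-])cc3[nH]2)c1` and compound 2 `O=[N+]([O-])c1cc(-c2nc3ccc([N+](=O)[O-])cc3[nH]2)cc(-c2nc3ccc([N+](=O)[O-])cc3[nH]2)c1` share a core; compound 3 `COc1cc(-c2nc3ccc(C(F)(F)F)cc3[nH]2)cc(-c2nc3ccc(C(F)(F)F)cc3[nH]2)c1` and compound 4 `O=[N+]([O-])c1cc(-c2nc3ccc(C(F)(F)F)cc3[nH]2)cc(-c2nc3ccc(C(F)(F)F)cc3[nH]2)c1` share another, and the difference between the two cores is not broken down here. In a functional assay on HeLa cells (Homo sapiens) for cytotoxicity, read by MTT assay, with a stated time of 48 h (a higher number here means a weaker inhibitor, a lower number a stronger inhibitor), compound 1 gives 1000 nM, and compound 2 gives 1200 nM. The change nitro in place of methoxy on an aromatic carbon produced a 1.2-fold higher number from compound 1 to compound 2 (0.08 log units; within the scatter). Compound 3 gives 8400 nM in this assay, standing highest of the three, beyond the scatter from both compound 1 and compound 2. Compound 4 carries the same change on its core, (nitro in place of methoxy on an aromatic carbon). Because the earlier step of a 1.2-fold higher number from compound 1 to compound 2 (0.08 log units; within the scatter) stayed within the scatter, the step from compound 3 to compound 4 is expected to be about as small, estimated as a 1.2-fold higher number from compound 3 to compound 4 (0.08 log units; within the scatter). Compound 4 is therefore expected to give about 10000 nM in this assay, between 4500 nM and 22000 nM.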

Compound 4, half-maximal inhibitory concentration: 1900 nM
Compound 4: the middle estimate sits 5.3-fold (0.72 log units) above what was measured; the measured number lies below the stated range.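

In this assay, nitro in place of methoxy on an aromatic carbon gave a 4.4-fold lower number from compound 3 to compound 4 (0.65 log units; beyond the scatter), so the step does not carry over unchanged between these two cores: the same change on two cores in this assay, a 1.2-fold higher number (0.08 log units; within the scatter) from compound 1 to compound 2 and a 4.4-fold lower number (0.65 log units; beyond the scatter) from compound 3 to compound 4, 5.3-fold (0.72 log units) apart, beyond the scatter of two such steps

Among these compounds, the size of this change therefore depends on the core for these two pairs, and a step within the scatter on one core was no guide to the step on the other. Two pairs do not show which feature of the cores accounts for the gap, or how the change would behave on any further core.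

Still open, from the compounds shown here alone, is the size of the same step on a core carrying an amine or a carboxylic acid where the two cores differ. Also open, going by these compounds, is whether an amine or a nitrile in place of the methoxy would follow the nitro on each core.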